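Urea series: chloro in place of ethyl on the aryl ring

This account rests on a few compounds, and the source may have more. Where it says the series, first, only, none or still open, it means among the compounds named here.

The series pairs a shared core with a phenylurea. Compound 1 `CCc1nc2ccccc2c(=O)n1NC(=O)Nc1ccccc1` carries the plain phenyl; in a functional assay on the whole organism (strain albino) with Mus musculus as the target, at a dose of 100 mg/kg by the intraperitoneal route (on this read-out lower numbers stand for less inhibition and higher numbers for more inhibition at the one dose given (going by the name of the read-out)), compound 1 gives 54%. Compound 2 `CCc1ccc(NC(=O)Nn2c(CC)nc3ccccc3c2=O)cc1` differs by ethyl in place of hydrogen on an aromatic carbon, and in this assay compound 2 gives 58%. Going by the values given here, the one measured step, a number 4 percentage points higher from compound 1 to compound 2 (within the scatter), is within the scatter. Among the compounds with values here, compound 2 therefore stands highest of the two numbers known, but its nearest neighbour, compound 1, is within the scatter of it, so no order between them can be claimed.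

Compound 3 `CCc1nc2ccccc2c(=O)n1NC(=O)Nc1ccc(Cl)cc1` is the next member, not yet measured. It differs from compound 2 by chloro in place of ethyl on an aromatic carbon. Within the data shown here, the only step that bears on this position is the one from compound 1 to compound 2, which was within the scatter, so a substituent change at this aromatic carbon has so far left this assay unmoved. On that basis the expected step is a number 1 percentage points lower from compound 2 to compound 3 (within the scatter), none beyond the scatter. Compound 3 is expected to give 57%, with a range from 42% to 72%.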

Compound 3, a percentage reported as inhibition, in the whole organism at one dose (the size of the read-out at that dose, not a potency): 52%
For compound 3 the middle estimate is 5 percentage points above the measured one; the range from low to high includes it.
By their numbers in this assay, from the lowest: compounds 3, 1 and 2 (each within the scatter of the next).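

In this assay the exchange of 4-ethylphenyl for 4-chlorophenyl gives a number 6 percentage points lower from compound 2 to compound 3 (within the scatter) and the addition of chloro in place of hydrogen at the same aromatic carbon gives a number 2 percentage points lower from compound 1 to compound 3 (within the scatter), so a halogen at this position now joins ethyl in leaving the read-out inside the usual spread. This position, on an aromatic carbon para to a large group, has thus carried hydrogen, ethyl and chloro, and compound 1, compound 2 and compound 3 all lie within the scatter of one another, with no order among them that can be claimed. At this one dose the three substituents shown therefore cannot be told apart, and no measurement at hand offers an explanation of that result.

Still open, on these data alone, is whether an amine, a carboxylic acid or a longer chain such as butyl on this same carbon would produce a step beyond the scatter. Also open, as far as these compounds go, is whether chloro or ethyl at another carbon of the ring, or on the shared core, would move the read-out at all.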